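Swapping a Ring Amine on Two Related Cores

The compounds below may be only part of what the source reports. "The series", "measured", "known", "first", "only" and "open" are said of these compounds alone.

Compound 1 `CN1CCN(c2ccc(Nc3ncc4c(n3)N(C3CCCC3)CC(=O)N4C)cc2)CC1` carries a 4-methylpiperazin-1-yl group, and in a functional assay on HeLa cells (Homo sapiens) for inhibition, read by MTT assay, with a stated time of 48 h (on this read-out lower numbers stand for stronger inhibition and higher numbers for weaker inhibition), compound 1 gives 6750 nM. Compound 2 `CN1C(=O)CN(C2CCCC2)c2nc(Nc3ccc(N4CCCCC4)cc3)ncc21` differs from it by piperidin-1-yl in place of 4-methylpiperazin-1-yl on an aromatic carbon; in this assay compound 2 gives 16900 nM, and the step of a 2.5-fold higher number from compound 1 to compound 2 (0.40 log units; beyond the scatter). Compound 3 `CN1CCN(c2ccc(Nc3ncc4c(n3)N(C3CCCC3)CC(=O)N4C)nc2)CC1` keeps the 4-methylpiperazin-1-yl group on a different core; the difference between the two cores is not broken down here. In this assay compound 3 gives 13100 nM, which lies within the scatter of compound 2 and of compound 1. Compound 4 `CN1C(=O)CN(C2CCCC2)c2nc(Nc3ccc(N4CCCCC4)cn3)ncc21` has not been measured. It differs from compound 3 by piperidin-1-yl in place of 4-methylpiperazin-1-yl on an aromatic carbon. This is the same kind of change as that between compound 1 and compound 2, though the place differs: there the ring was of carbon only, here the ring holds one nitrogen and the group stands two atoms from the ring nitrogen, in both cases para to a large group. Because the earlier change gave a 2.5-fold higher number from compound 1 to compound 2 (0.40 log units; beyond the scatter), compound 4 is expected to show a step of roughly a 2.3-fold higher number from compound 3 to compound 4 (0.36 log units; beyond the scatter) in this assay, resting on that single precedent. Compound 4 is estimated at 30000 nM, with an expected range from 12000 nM to 80000 nM.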

Compound 4, half-maximal inhibitory concentration: > 30000 nM
Compound 4 was reported as a limit; the forecaster's own chance of this, stated with the estimate: 15%; the middle value lies on the limit itself.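

Compound 4 gives > 30000 nM in this assay, and this is a limit of the assay, not an exact number. Even so, a step can be read: putting piperidin-1-yl in place of 4-methylpiperazin-1-yl gives an at least 2.2-fold higher number from compound 3 to compound 4 (0.35 log units; beyond the scatter), so the change moves the number the same way on both cores, as this comparison shows: the same change on two cores in this assay, a 2.5-fold higher number (0.40 log units; beyond the scatter) from compound 1 to compound 2 and an at least 2.2-fold higher number (0.35 log units; beyond the scatter) from compound 3 to compound 4; the limit leaves it open whether they differ. This shows that the direction carried over between these two cores, but it does not show whether the size of the step carried over too, since the second step rests on a limit: the limit of > 30000 nM in this assay, at which 1 of the 4 values shown sits.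

The compounds shown leave open how other ring amines, such as morpholin-4-yl or a piperazin-1-yl group without its methyl, would read on either core. They also leave open whether an open-chain amine such as dimethylamino, placed on the same aromatic carbon, would follow the same direction.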